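Chloro for hydrogen on the shared core: compound 3

This account rests on a few compounds, and the source may have more. Where it says the series, first, only, none or still open, it means among the compounds named here.

Measured so far:
compound 1 `ClCc1ccccc1Cn1cnc2ncnc(Cl)c21`: 10700 nM
compound 2 `ClCc1ccc(Cn2cnc3ncnc(Cl)c32)cc1`: 66100 nM

In a functional assay on UO-31 cells (Homo sapiens) for cytotoxicity, read by sulforhodamine B assay, with a stated time of 48 h (on this read-out lower numbers stand for stronger inhibition of growth and higher numbers for weaker inhibition of growth), compound 2 gives the highest of the two numbers; its nearest neighbour is compound 1, whose value is lower by more than the usual scatter. Compound 3 `ClCc1ccc(Cn2cnc3nc(Cl)nc(Cl)c32)cc1` differs from compound 2 by a single change: chloro in place of hydrogen on an aromatic carbon. Among the measured compounds shown here, no measured pair of this kind is available, so the step for compound 3 is expected to be small, a 1.3-fold lower number from compound 2 to compound 3 (0.12 log units; within the scatter), with direction uncertain and probably not beyond the scatter. Compound 3 is accordingly estimated at 50000 nM, within 15000 nM to 150000 nM.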

Compound 3, concentration for total growth inhibition: 2880 nM
For compound 3 the middle estimate is 17-fold (1.24 log units) above the measured one; measured number outside the range, below it.
By their numbers in this assay, from the lowest: compound 3; then compound 1; then compound 2.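

In this assay, chloro in place of hydrogen on the aromatic carbon between two ring nitrogen atoms gives a 23-fold lower number from compound 2 to compound 3 (1.36 log units; beyond the scatter). This position, which carries hydrogen in compound 1 and compound 2, is therefore not indifferent to substitution: a single chlorine atom moves the read-out by a large step. Nothing available here offers a reason for the step. Going by these compounds, it remains open whether this shift is particular to chloro or would also follow from an amine or a methyl group at this position. On these data alone, whether chloro has a similar effect on compound 1 also remains open.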